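A second nitro on a weak inhibitor

The compounds below may be only part of what the source reports. "The series", "measured", "known", "first", "only" and "open" are said of these compounds alone.

In a functional assay on P388 cells (Mus musculus) for inhibition (on this read-out higher numbers stand for weaker inhibition and lower numbers for stronger inhibition), compound 1 `COc1ccc(/C=C/c2ccc3ccccc3c2)cc1F` gives 4490 nM. Compound 2 `COc1ccc(/C=C/c2ccc3ccccc3c2)cc1[N+](=O)[O-]` gives only a limit of the assay, > 5000 nM. Compound 3 `COc1c([N+](=O)[O-])cc(/C=C/c2ccc3ccccc3c2)cc1[N+](=O)[O-]` differs from compound 2 by nitro in place of hydrogen on an aromatic carbon, ortho to a methoxy group. For the measured compounds named here, the one measured step that bears on this also brings in a nitro, in place of fluoro, and it is an at least 1.1-fold higher number from compound 1 to compound 2 (0.04 log units; that floor lies within the scatter). On the strength of that step, no marked gain in inhibition is expected in this assay, and the expected step is a step that the limit leaves unreadable from compound 2 to compound 3. For compound 3 the estimate is 7000 nM, within an expected range of 3000 nM to 20000 nM.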

Compound 3, half-maximal inhibitory concentration: > 5000 nM
Compound 3 ended at the assay's limit; the forecaster's own chance of this, stated with the estimate: 75%; the middle value is on the limit's open side.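

No step from compound 2 to compound 3 can be read, because both values are limits and not numbers: the limit of > 5000 nM in this assay, at which 2 of the 3 values shown sit.

The compounds shown leave open whether the added nitro changes inhibition at all in this assay.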